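Swapping a ring-bearing arm for an amide-linked thiazole

This account rests on a few compounds, and the source may have more. Where it says the series, first, only, none or still open, it means among the compounds named here.

For the measured compounds named here, compound 2 `CCCCNc1nc(N)nc2c1CN(Cc1ccco1)CC2` gives 0.08 uM in an assay on HEK293 cells for agonist activity at Toll-like receptor 8 (Homo sapiens), read by a luciferase reporter, with a stated time of 6 h; a higher number here means that more compound is needed for the effect, a lower number that less compound is needed; it has the highest of the two numbers measured, but its only neighbour, compound 1 `CCCCNc1nc(N)nc2c1CN(Cc1ccccn1)CC2` at 0.07 uM, lies within the scatter, so the two cannot be ordered. The step of a 1.1-fold higher number from compound 1 to compound 2 (0.06 log units; within the scatter) shows that exchanging one ring for another on that arm changed little. Compound 3 `CCCCNc1nc(N)nc2c1CN(C(=O)c1csc(C)n1)CC2` differs from compound 2 by (2-methyl-1,3-thiazol-4-yl)carbonyl in place of (furan-2-yl)methyl on an amine nitrogen in a ring. Going by the values given here, no measured step covers a carbonyl at this nitrogen, so the expectation rests on analogy alone: a modest increase, a 3.8-fold higher number from compound 2 to compound 3 (0.57 log units; beyond the scatter), is expected, giving compound 3 an estimated 0.3 uM with a range from 0.05 uM to 2 uM.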

Compound 3, minimum effective concentration: 1.8 uM
Estimate against measurement, compound 3: 6.0-fold (0.78 log units) below; low and high end bracket the measured number.
By their numbers in this assay, from the lowest: compounds 1 and 2 (each within the scatter of the next); then compound 3.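

In this assay, the amine nitrogen in the ring carries (furan-2-yl)methyl or (pyridin-2-yl)methyl with no readable difference, but (2-methyl-1,3-thiazol-4-yl)carbonyl gives a large change: a 23-fold higher number from compound 2 to compound 3 (1.35 log units; beyond the scatter) and a 26-fold higher number from compound 1 to compound 3 (1.41 log units; beyond the scatter). This position is therefore not indifferent to what it carries, and much more compound is needed with this group in place. Nothing available explains the change. The swap alters both the ring and the link to the nitrogen, so the compounds shown do not separate the two. A furan-2-carbonyl group or a (2-methyl-1,3-thiazol-4-yl)methyl group at this nitrogen would do so.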